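Working notes: methyl for chloro on the aryl ketone

A few compounds are considered here, and "the series" means these few. Any claim that something is new, unique, unknown or untested is made for them only; others in the source may bear on it.

Measured so far:
compound 1 `O=C(/C=C/C1=Cc2ccccc2OC1)c1ccc(Cl)cc1` — 56.1%
compound 2 `O=C(/C=C/C1=Cc2ccccc2OC1)c1ccc(Cl)cc1Cl` — 53.3%

In a functional assay on the whole organism for inhibition, with Mus musculus as the target, with a stated time of 1 h, at a dose of 30 mg/kg by the intraperitoneal route (on this read-out lower numbers stand for less inhibition and higher numbers for more inhibition at the one dose given (going by the name of the read-out)), compound 1 gives the higher number of the two, but the step of a number 2.8 percentage points lower from compound 1 to compound 2 (within the scatter) is within the scatter, so the pair cannot be told apart. Compound 3 `Cc1ccc(C(=O)/C=C/C2=Cc3ccccc3OC2)cc1` differs from compound 1 by methyl in place of chloro on an aromatic carbon. For the measured compounds named here, no measured step exchanges chloro for methyl; the one step known, chloro entering, stayed within the scatter. The expected step from compound 1 to compound 3 is therefore a number 4.1 percentage points lower from compound 1 to compound 3 (within the scatter), none beyond the scatter. Compound 3 is estimated at 52%, with a range of 36% to 66%.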

Compound 3, a percentage reported as inhibition, in the whole organism at one dose (the size of the read-out at that dose, not a potency): 53.1%
Compound 3: middle estimate off by 1.1 percentage points, on the low side; low and high end bracket the measured number.
By their numbers in this assay, from the lowest: compounds 3, 2 and 1 (each within the scatter of the next).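

In this assay, for the compounds shown here, methyl in place of chloro gives a number 3 percentage points lower from compound 1 to compound 3 (within the scatter) and so is the first exchange of the chloro itself, not an addition to the ring. At this place, para to a large group, compound 3 carries no chlorine at all, so a chlorine on this ring is not needed for a number of this size at the one dose given. No available evidence bears on the reason for this result.

Still open, as far as these compounds go, is whether an amine or a carboxylic acid at this place would stay within the scatter of compound 1. Also open, from the compounds shown here alone, is whether a longer chain such as butyl would do so.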